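Adding a Methoxy Group: From Compound 3 to Compound 4

A few compounds are considered here, and "the series" means these few. Any claim that something is new, unique, unknown or untested is made for them only; others in the source may bear on it.

In a functional assay on SMMC-7721 cells (Homo sapiens) for antiproliferative activity, read by MTT assay, with a stated time of 72 h (a lower number here means a stronger inhibitor, a higher number a weaker inhibitor), the measured compounds stand as follows:

compound 1, `CN(C(=O)c1ccccc1)c1ccc2[nH]c(-c3n[nH]c4ccccc34)cc2n1`: 12500 nM
compound 2, `COc1cccc(C(=O)N(C)c2ccc3[nH]c(-c4n[nH]c5ccccc45)cc3n2)c1`: 22000 nM
compound 3, `COc1ccc(S(=O)(=O)N(C)c2ccc3[nH]c(-c4n[nH]c5ccccc45)cc3n2)cc1`: 13000 nM

Compound 1 and compound 2 share one core and differ by a single change, (methoxy in place of hydrogen on an aromatic carbon). That change produced a 1.8-fold higher number from compound 1 to compound 2 (0.25 log units; within the scatter), a step within the scatter, so the two values are not distinguishable on this evidence. Compound 3 carries a different core from compound 1; the difference between the two cores is not broken down here. What their values show is that compound 3 and compound 1 sit close together, within the scatter of each other, and the same holds for compound 3 against compound 2.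

Compound 4, `COc1ccc(S(=O)(=O)N(C)c2ccc3[nH]c(-c4n[nH]c5ccccc45)cc3n2)cc1OC`, has not yet been measured. It differs from compound 3 by methoxy in place of hydrogen on an aromatic carbon. Among the compounds with values here, this is the same kind of change as the one from compound 1 to compound 2, though not the same: in compound 4 the entering group sits ortho to a methoxy group, whereas in compound 2 the entering group is only meta to a large group.

Within the data shown here, since the one measured instance of this kind of change gave a 1.8-fold higher number from compound 1 to compound 2 (0.25 log units; within the scatter), the step from compound 3 to compound 4 is expected to be a 1.5-fold higher number from compound 3 to compound 4 (0.19 log units; within the scatter), resting on that single precedent. Compound 4 is therefore estimated at 20000 nM in this assay, with a range from 8000 nM to 50000 nM.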

Compound 4, half-maximal inhibitory concentration: 26600 nM
Compound 4: middle estimate off by 1.3-fold (0.12 log units), on the low side; measured number inside the range.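

In this assay, methoxy in place of hydrogen on an aromatic carbon, which turns 4-methoxyphenyl into 3,4-dimethoxyphenyl, gave a 2.0-fold higher number from compound 3 to compound 4 (0.31 log units; beyond the scatter), a modest step. Set beside the one earlier instance of this kind of change, the step on the second core cannot be told apart from the first: the same change on two cores in this assay, a 1.8-fold higher number (0.25 log units; within the scatter) from compound 1 to compound 2 and a 2.0-fold higher number (0.31 log units; beyond the scatter) from compound 3 to compound 4, 1.2-fold (0.07 log units) apart, within the scatter of two such steps The two steps therefore agree in size across these two cores, but only two pairs stand behind that agreement, the first step taken alone lies within the scatter, and the entering group sits ortho to a methoxy group only in compound 4, so this does not show that the change would behave alike on any further core.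

Among the compounds shown, methoxy is the only group that enters on the aromatic ring, which leaves open whether a fluoro group, a hydroxyl group or an amine at the same place would give a step of similar size. From the compounds shown here alone, it also remains open how a carboxylic acid or a longer chain in place of the entering methoxy would read in this assay.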